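This account rests on a few compounds, and the source may have more. Where it says the series, first, only, none or still open, it means among the compounds named here.

Measured compounds:
compound 1 `O=C(N[C@H]1C[C@@H](C(=O)NO)N(S(=O)(=O)c2ccc(Oc3ccccc3)cc2)C1)c1ccc2no[n+]([O-])c2c1` gives 3560 nM in a functional assay on K562 cells (Homo sapiens) for antiproliferative activity, read by MTT assay, with a stated time of 48 h; on this read-out higher numbers stand for weaker inhibition and lower numbers for stronger inhibition;
compound 2 `COc1ccc(/C=C/C(=O)N2C[C@@H](NC(=O)c3ccc4no[n+]([O-])c4c3)C[C@H]2C(=O)NO)cc1OC` gives 4610 nM in this assay.

Only these two numbers are known. Compound 2 stands within the scatter of compound 1, so the two cannot be separated on this read-out. Compound 3 `COc1ccc(/C=C/C(=O)N2C[C@@H](NC(=O)c3cccc4no[n+]([O-])c34)C[C@H]2C(=O)NO)cc1OC` differs from compound 2 by a group of 10 heavy atoms (6 carbon, 2 nitrogen, 2 oxygen; one five-membered aromatic ring with 3 hetero atoms, one six-membered aromatic ring of carbon only) in place of a group of 10 heavy atoms (6 carbon, 2 nitrogen, 2 oxygen; one five-membered aromatic ring with 3 hetero atoms, one six-membered aromatic ring of carbon only), on a carbonyl carbon; the two share every atom and differ only in how the ring system is joined to the carbonyl carbon. Within the data shown here, no measured pair shows what such a step does, so no shift beyond the scatter is expected. The step from compound 2 to compound 3 is estimated at a 1.1-fold higher number from compound 2 to compound 3 (0.04 log units; within the scatter). Compound 3 is expected to give 5000 nM, likely between 2000 nM and 12500 nM.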

Compound 3, half-maximal inhibitory concentration: 11200 nM
Beside the measured number, compound 3's estimate is 2.2-fold (0.35 log units) below it; the range from low to high includes it.
By their numbers in this assay, from the lowest: compounds 1 and 2 (each within the scatter of the next); then compound 3.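

In this assay, rejoining the ring system to the carbonyl carbon while keeping every atom gives a 2.4-fold higher number from compound 2 to compound 3 (0.39 log units; beyond the scatter) and so shows that the point of attachment alone can move this read-out, which compounds 1 and 2 could not show. This modest step rests on a single pair of compounds. Nothing available accounts for the shift.

From the compounds shown here alone, it remains open whether the same change would have a similar effect on compound 1. Going by these compounds, it is also open how a pyridine ring on this carbonyl carbon would compare.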